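Cyano on the benzyl of compound 3: an expectation

The source may hold more compounds than are shown below. What is called first, only, known or untested is meant among the compounds shown, and "the series" means these compounds.

Compound 1 `CC(C)n1ncc2c(C(=O)NCc3cn(-c4ccccc4F)nn3)cccc21`: > 40000 nM
Compound 2 `CC(C)n1ncc2c(C(=O)NCc3cn(-c4ccc(C(F)(F)F)cc4)nn3)cccc21`: > 40000 nM
Compound 3 `CC(C)n1ncc2c(C(=O)NCc3cn(Cc4ccccc4)nn3)cccc21`: 9170 nM

In a functional assay on MCF7 cells (Homo sapiens) for inhibition, read by MTT assay, with a stated time of 72 h (on this read-out higher numbers stand for weaker inhibition and lower numbers for stronger inhibition), compound 1 returns > 40000 nM, which is a limit of the assay and not a number. Compound 2 likewise returns > 40000 nM, again a limit. Compound 3 is the only one of the three with a number, 9170 nM in this assay. The step of an at least 4.3-fold lower number from compound 1 to compound 3 (0.63 log units; beyond the scatter) and the step of an at least 4.3-fold lower number from compound 2 to compound 3 (0.63 log units; beyond the scatter) both point the same way, while a step that the two limits leave unreadable from compound 1 to compound 2 remains unreadable, as the limit of > 40000 nM in this assay, at which 2 of the 3 values shown sit, shows.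

Compound 4 `CC(C)n1ncc2c(C(=O)NCc3cn(Cc4ccc(C#N)cc4)nn3)cccc21` differs from compound 3 by cyano in place of hydrogen on an aromatic carbon. For the measured compounds named here, no measured step changes a substituent on the benzyl itself: the steps to compound 3 exchange the whole group on the aromatic nitrogen, and the step between compound 1 and compound 2 sits at the limit. Nothing measured therefore bears on this change, and in this assay the expected step is a 1.0-fold lower number from compound 3 to compound 4 (0.01 log units; within the scatter), none beyond the scatter. Compound 4 is estimated at 9000 nM, between 3000 nM and 30000 nM.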

Compound 4, half-maximal inhibitory concentration: > 40000 nM
Compound 4: only a limit was reported; the forecaster's own chance of this, stated with the estimate: 20%; middle value at least 4.4-fold (0.64 log units) from the limit.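

In this assay, for the compounds shown here, the earlier steps had exchanged the whole group on the aromatic nitrogen, whereas here a change on the benzyl itself has a readable effect: cyano in place of hydrogen, para to a large group, gives an at least 4.3-fold higher number from compound 3 to compound 4 (0.63 log units; beyond the scatter). The benzyl of compound 3 therefore does not tolerate every substituent at this position, and a single small addition is enough to lose the measurable activity seen with the unsubstituted group. Compound 3 remains the only one of the four with a number, and the other values are limits of the assay: the limit of > 40000 nM in this assay, at which 3 of the 4 values shown sit.

The steps from compound 1 and compound 2 to compound 4 cannot be read, since both ends of each are limits. From the compounds shown here alone, whether a fluorine atom, a methoxy group or an amine at this position would keep, improve or lose the number of compound 3 remains open.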